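Replacing the methyl of compound 2 with a larger ring

The compounds below may be only part of what the source reports. "The series", "measured", "known", "first", "only" and "open" are said of these compounds alone.

Values so far in an ADME assay on microsomes from liver (Homo sapiens) for metabolic stability, with a stated time of 60 min, tested at 1 uM; on this read-out lower numbers stand for a less stable compound and higher numbers for a more stable compound:
compound 1 `COc1cc(-c2cnn3cc(OC)c(-c4cnn(C)c4)nc23)ccn1` gives 43%
compound 2 `COc1cc(-c2cnn3cc(OC)c(C)nc23)ccn1` gives 44%
compound 3 `COc1cn2ncc(-c3ccnc(OC(C)C)c3)c2nc1-c1cnn(C)c1` gives 32%

Compound 2 at 44% is level with compound 1 within the scatter, and compound 3 lies below it by more than the scatter. The next structure is compound 4 `COc1cc(-c2cnn3cc(OC)c([C@H]4COC(C)(C)C4)nc23)ccn1`, and the change is a group of 7 heavy atoms (6 carbon, 1 oxygen; one five-membered non-aromatic ring with 1 hetero atom) in place of one carbon atom, on an aromatic carbon. The new group is attached on an aromatic carbon of a six-membered aromatic ring with 2 nitrogen.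

Among the compounds with values here, two measured steps bear on this. The same aromatic carbon has already been varied, and a number 1 percentage points higher from compound 1 to compound 2 (within the scatter) shows no change beyond the scatter between methyl and 1-methyl-1H-pyrazol-4-yl. Within the data shown here, that step involves an aromatic group, however, and no measured compound carries a five-membered non-aromatic ring. The other step, a number 11 percentage points lower from compound 1 to compound 3 (beyond the scatter), is modest and lies elsewhere on the molecule, but it is the only measured case in which a larger non-aromatic group enters. Taken together, these two steps give only weak guidance, and a modest fall in this assay seems the most likely outcome. The expected change is a number 11 percentage points lower from compound 2 to compound 4 (beyond the scatter). For compound 4 the estimated value is 33%, within an expected range of 15% to 52%.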

Compound 4, percent of the compound remaining: 21%
Compound 4: middle estimate off by 12 percentage points, on the high side; the range from low to high includes it.
By their numbers in this assay, from the lowest: compound 4; then compound 3; then compounds 1 and 2 (each within the scatter of the next).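

Notes on the position on an aromatic carbon, next to the ring nitrogen: in this assay the earlier pair gave a number 1 percentage points higher from compound 1 to compound 2 (within the scatter), which left open whether a substituent here matters at all, but a number 23 percentage points lower from compound 2 to compound 4 (beyond the scatter) shows that the read-out does respond to a change at this carbon. The comparison with the aromatic group gives a number 22 percentage points lower from compound 1 to compound 4 (beyond the scatter), so the five-membered non-aromatic ring with 1 hetero atom stands apart from both methyl and 1-methyl-1H-pyrazol-4-yl, and heavy-atom count alone does not order the three groups, since 1-methyl-1H-pyrazol-4-yl stays level with methyl while the group of 7 heavy atoms does not. Nothing measured here gives a reason for this drop.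

The compounds shown do not separate the contributions of the ring oxygen, the two methyl groups on the ring and the defined stereocentre, and the opposite stereoisomer is absent from this set. Also open, as far as these compounds go, is how a plain cyclopentyl ring, a tert-butyl group or a ring amine such as piperidine would compare at this carbon.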